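One Chain Change in a Thinly Measured Pair

The source may hold more compounds than are shown below. What is called first, only, known or untested is meant among the compounds shown, and "the series" means these compounds.

Compound 1 (`O=S(=O)(c1ccccc1)c1c(OCCCCCCO)no[n+]1[O-]`) and compound 2 (`O=C(COCCOc1no[n+]([O-])c1S(=O)(=O)c1ccccc1)NO`) share a core but carry different chains. In a functional assay on U-937 cells (Homo sapiens) for inhibition, read by MTT assay, with a stated time of 48 h (on this read-out higher numbers stand for weaker inhibition and lower numbers for stronger inhibition), compound 1 offers no number ("not determined" (no result reported)). Within the data shown here, compound 2 gives a half-maximal inhibitory concentration (8150 nM), the only number available, so it cannot yet be ranked as strong or weak against a neighbour.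

Compound 3 (`O=C(NO)OCCOCCOc1no[n+]([O-])c1S(=O)(=O)c1ccccc1`) keeps the core of compound 2 and changes the end of the chain (((hydroxycarbamoyl)oxy)methyl in place of hydroxycarbamoyl on a saturated chain carbon bound to an oxygen on a saturated carbon). It has ((hydroxycarbamoyl)oxy)methyl in place of hydroxycarbamoyl on a saturated chain carbon bound to an oxygen on a saturated carbon. Among the measured compounds shown here, no measured pair shows what a change of this kind does, so the data offer no direct guide.

With compound 2 at (8150 nM) as the sole anchor, no step beyond the usual scatter is expected in this assay, and neither direction can be firmly favoured. The expected step is therefore small (a 1.2-fold lower number from compound 2 to compound 3 (0.07 log units; within the scatter)). For compound 3 the estimated value is (7000 nM), with a wide expected range from (2500 nM) to (20000 nM).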

Compound 3, half-maximal inhibitory concentration: 12100 nM
Estimate against measurement, compound 3: 1.7-fold (0.24 log units) below; measured number inside the range.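

In this assay, among these compounds, putting ((hydroxycarbamoyl)oxy)methyl in place of hydroxycarbamoyl on a saturated chain carbon bound to an oxygen on a saturated carbon gives a 1.5-fold higher number from compound 2 to compound 3 (0.17 log units; within the scatter), and this is the first measured reading of any change at this place. Among the compounds shown here, the pair therefore does not separate the two chain ends: the entering group has 6 heavy atoms and 3 hydrogen-bond acceptors against 4 and 2 for the leaving group, yet the read-out gives no difference beyond the scatter, while no step to compound 1 can be read. Nothing supplied offers an explanation for this result, or any measured property of either chain end.

Both measured compounds carry the hydroxycarbamoyl group, so this pair leaves open whether a carboxylic acid or an amine at the end of the chain would give a number like theirs. It also leaves open whether a longer chain, beyond 2-((hydroxycarbamoyl)oxy)ethoxy, would produce a step larger than the scatter, as a single step within the scatter sets no trend in either direction.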